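The source may report more compounds than this note shows. Statements on the series, on what has been measured and on what is new or still open speak of the compounds shown alone.

In an ADME assay on Huh-7 cells (Homo sapiens) for cytotoxicity (on this read-out lower numbers stand for higher toxicity in this test and higher numbers for lower toxicity in this test), compound 1 `CC#CCN1c2ccc(OC)cc2[C@]23CCC(=O)N(CCOC)C2=NC(C(=O)OC)=C(C(=O)OC)C13` reads > 320000 nM, which is a limit of the assay and not a number. For the measured compounds named here, compound 2 `C=CCN1c2ccc(OC)cc2[C@]23CCC(=O)N(Cc4ccccc4)C2=NC(C(=O)OC)=C(C(=O)OC)C13` gives 127000 nM, the only actual number so far. Compound 3 `C=CCN1c2ccc(OC)cc2[C@]23CCC(=O)N(Cc4cc(OC)c(OC)c(OC)c4)C2=NC(C(=O)OC)=C(C(=O)OC)C13` keeps the core of compound 2 and changes one group: 3,4,5-trimethoxyphenyl in place of phenyl on a saturated chain carbon bound to an amide-type nitrogen in a ring. Going by the values given here, no measured pair yet shows what such a swap does in this assay, so no change beyond the scatter is expected, and no direction can be favoured. The expected step runs a 1.1-fold lower number from compound 2 to compound 3 (0.02 log units; within the scatter). For compound 3 the estimated value is 120000 nM, within an expected range of 50000 nM to 300000 nM.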

Compound 3, half-maximal cytotoxic concentration: 5300 nM
Estimate against measurement, compound 3: 23-fold (1.35 log units) above; measured number outside the range, below it.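

The swap at this position, a saturated chain carbon bound to an amide-type nitrogen in a ring, clearly matters in this assay: 3,4,5-trimethoxyphenyl in place of phenyl gives a 24-fold lower number from compound 2 to compound 3 (1.38 log units; beyond the scatter), so toxicity in this test rises. The aromatic ring stays the same, so the step comes with the added methoxy groups. Neither end of this step is an assay limit, so its size can be read in full: the limit of > 320000 nM in this assay, at which 1 of the 3 values shown sits.

From the compounds shown here alone, whether a lone methoxy group on the phenyl ring gives part of this step stays open. So does what a hydroxyl or an amine there would do.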